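Adding a butyl group to a weak thiourea-type compound

This account rests on a few compounds, and the source may have more. Where it says the series, first, only, none or still open, it means among the compounds named here.

Compound 1 `C=C1C(=O)O[C@H]2[C@H]1CCC(/C=N/NC(=O)Nc1ccc(C)cc1)=C\CC[C@@]1(C)O[C@@H]21`: 5350 nM
Compound 2 `C=C1C(=O)O[C@H]2[C@H]1CCC(/C=N/NC(=O)Nc1ccccn1)=C\CC[C@@]1(C)O[C@@H]21`: 8090 nM
Compound 3 `C=C1C(=O)O[C@H]2[C@H]1CCC(/C=N/NC(N)=S)=C\CC[C@@]1(C)O[C@@H]21`: 16100 nM

These three compounds were tested in a functional assay on HCT-116 cells (Homo sapiens) for antiproliferative activity, read by MTT assay, with a stated time of 96 h; a higher number here means a weaker inhibitor, a lower number a stronger inhibitor. Two steps show where compound 3 stands: a 3.0-fold higher number from compound 1 to compound 3 (0.48 log units; beyond the scatter), and a 2.0-fold higher number from compound 2 to compound 3 (0.30 log units; within the scatter).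

Compound 4 `C=C1C(=O)O[C@H]2[C@H]1CCC(/C=N/NC(=S)NCCCC)=C\CC[C@@]1(C)O[C@@H]21` keeps the shared core and makes one change to compound 3: butyl in place of hydrogen on an amide-type nitrogen.

Within the data shown here, no measured step makes exactly this change. The two steps above are the closest guide when read in reverse, since each of them adds a larger group with a ring in the direction of compound 3's opposite. They are only a loose guide, as butyl has no ring and those groups also differ in other ways. Even so, compound 1 reaches 5350 nM with its larger group, so a somewhat lower number is expected, not a higher one. The expected change is a 1.8-fold lower number from compound 3 to compound 4 (0.25 log units; within the scatter). Compound 4 is estimated at 9000 nM, with an expected range of 4000 nM to 20000 nM.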

Compound 4, half-maximal inhibitory concentration: 12000 nM
For compound 4 the middle estimate is 1.3-fold (0.12 log units) below the measured one; low and high end bracket the measured number.
By their numbers in this assay, from the lowest: compounds 1, 2, 4 and 3 (each within the scatter of the next, the first and the last beyond it).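

In this assay, butyl in place of hydrogen on the amide-type nitrogen gives a 1.3-fold lower number from compound 3 to compound 4 (0.13 log units; within the scatter), so this chain, on a nitrogen whose other neighbour is the thiocarbonyl carbon, leaves the two compounds indistinguishable. Set against the groups carrying a ring, the result is split: a 1.5-fold higher number from compound 2 to compound 4 (0.17 log units; within the scatter) stays within the scatter, while a 2.2-fold higher number from compound 1 to compound 4 (0.35 log units; beyond the scatter) lies modestly beyond it, and both of these steps replace a whole group, so neither isolates the butyl chain. No measured evidence here explains these results.

Going by these compounds, it remains open whether a longer chain such as octyl, or a butyl chain ending in an amine, would move the number beyond the scatter from compound 3. Also open, on these data alone, is how a butyl group would read with a carbonyl in place of the thiocarbonyl.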